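This account rests on a few compounds, and the source may have more. Where it says the series, first, only, none or still open, it means among the compounds named here.

Among the measured compounds shown here, in an in vivo ADME assay on the whole organism (strain Sprague-Dawley) for pharmacokinetics, with Rattus norvegicus as the target, at a dose of 10 mg/kg by the oral route (on this read-out lower numbers stand for lower oral bioavailability and higher numbers for higher oral bioavailability), compound 1 `CC(C)(c1ccccc1)c1nc2c(C(F)(F)F)cccc2c(C(=O)O)c1O` gives 93%, the higher of the two numbers so far. Compound 2 `O=C(O)c1c(O)c(C2(c3ccccc3)CC2)nc2c(C(O)(C(F)(F)F)C(F)(F)F)cccc12` gives 44%, a gap well beyond the usual scatter of repeated measurements. Compound 3 `O=C(O)c1c(O)c(C2Cc3ccccc3C2)nc2c(C(F)(F)F)cccc12` has not yet been measured. It keeps the core of compound 1 and changes one group: 2,3-dihydro-1H-inden-2-yl in place of 1-methyl-1-phenylethyl on an aromatic carbon. In words, 2,3-dihydro-1H-inden-2-yl stands in place of 1-methyl-1-phenylethyl on an aromatic carbon, next to the ring nitrogen and ortho to a hydroxy group. For the measured compounds named here, no measured pair of compounds differs in one place only, so the data offer no direct guide to this swap. Compound 1 already sits near the top of the scale at 93%, so a move beyond the scatter is expected to be downward. The estimated change is a number 28 percentage points lower from compound 1 to compound 3 (beyond the scatter). For compound 3 the expected value is 65%, with an estimated range of 35% to 90%.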

Compound 3, oral bioavailability in the Rattus norvegicus assay: 49%
The estimate for compound 3 lay 16 percentage points above the measured number, and the stated range covers the measured number.
By their numbers in the Rattus norvegicus assay, from the lowest: compounds 2 and 3 (each within the scatter of the next); then compound 1.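

Among the compounds shown here, this is the first reading of a single change on the aromatic carbon next to the ring nitrogen and ortho to a hydroxy group. In the Rattus norvegicus assay, 2,3-dihydro-1H-inden-2-yl in place of 1-methyl-1-phenylethyl gives a number 44 percentage points lower from compound 1 to compound 3 (beyond the scatter), even though both groups hold 9 heavy atoms, all carbon, and neither has hydrogen-bond donors or acceptors. In a physicochemical assay for solubility, at pH 6.6 (on this read-out higher numbers stand for higher solubility and lower numbers for lower solubility), compound 1 gives 2810 ug/mL and compound 3 gives 700 ug/mL. The swap also lowers the number in the physicochemical assay, a possible link to the loss of oral bioavailability, though one pair of compounds cannot establish a cause: the measured solubility of compound 1, 2810 ug/mL, and of compound 3, 700 ug/mL, a 4.0-fold lower number (0.60 log units; beyond the scatter)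

For the compounds shown here, whether the drop is tied to the five-membered non-aromatic ring in particular remains open, as only one swap at this position can be read. From the compounds shown here alone, how an amine or a longer carbon chain on this aromatic carbon would behave also remains unknown.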